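Ortho alkoxy extension on the arylpiperazine of compound 3

This account rests on a few compounds, and the source may have more. Where it says the series, first, only, none or still open, it means among the compounds named here.

Measured compounds:
compound 1, `COc1ccccc1N1CCN(CCCNc2ncccc2C(=O)NC(C)(C)C)CC1`, 1.59 nM in an assay on isolated protein for displacement of a labelled ligand from Alpha-1A adrenergic receptor (Bos taurus); on this read-out higher numbers stand for weaker inhibition and lower numbers for stronger inhibition
compound 2, `COc1ccccc1N1CCN(CCCNc2ccncc2C(=O)N(C(C)C)C(C)C)CC1`, 1.59 nM in this assay
compound 3, `CN(C)C(=O)c1cccnc1NCCCN1CCN(c2ccccc2)CC1`, 2 nM in this assay

Compound 3 stands at the highest of the three numbers, yet its distance to compound 1 and to compound 2 lies within the scatter, so no order among the three can be read from these values. Among the compounds with values here, no single-change step between measured compounds is available.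

Compound 4, `CN(C)C(=O)c1cccnc1NCCCN1CCN(c2ccccc2OCC2CC2)CC1`, differs from compound 3 by cyclopropylmethoxy in place of hydrogen on an aromatic carbon. Within the data shown here, with no comparable measured step to lean on, the expectation is a change of about the scatter or less, in this assay leaning towards a lower number, as a 1.5-fold lower number from compound 3 to compound 4 (0.19 log units; within the scatter). Compound 4 is estimated at 1.3 nM, within 0.4 nM to 4.5 nM, because compound 3 gives 2 nM.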

Compound 4, inhibition constant: 0.0794 nM
Beside the measured number, compound 4's estimate is 16-fold (1.21 log units) above it; measured number outside the range, below it.
By their numbers in this assay, from the lowest: compound 4; then compounds 1, 2 and 3 (each within the scatter of the next).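

In this assay the aromatic carbon ortho to a large group responds strongly to substitution: cyclopropylmethoxy in place of hydrogen gives a 25-fold lower number from compound 3 to compound 4 (1.40 log units; beyond the scatter) and sets compound 4 apart, whereas compounds 1, 2 and 3 lie within the scatter of one another. The data offer no explanation for the size of this step.

On these data alone, whether cyclobutylmethoxy or a longer chain such as butoxy on the same carbon would match compound 4 remains open. Also open, as far as these compounds go, is whether the step carries over to the amides of compound 1 and compound 2.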